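A few compounds are considered here, and "the series" means these few. Any claim that something is new, unique, unknown or untested is made for them only; others in the source may bear on it.

Measured compounds in a functional assay (Homo sapiens) for inhibition; on this read-out higher numbers stand for weaker inhibition and lower numbers for stronger inhibition:
compound 1 `COc1cccc(OC/C=C(\C)CC/C=C(\C)C2CC(=O)C(C)(C)O2)c1`: 33.8 ug/mL
compound 2 `C/C(=C\COc1ccccc1)CC/C=C(\C)C1CC(=O)C(C)(C)O1`: 27.6 ug/mL
compound 3 `C/C(=C\COc1ccc2ccccc2c1)CC/C=C(\C)C1CC(=O)C(C)(C)O1`: 26.9 ug/mL

Compound 2 stands at the second highest of the three numbers in this assay; compound 3, with 26.9 ug/mL, is nearest to it, and compound 1 furthest, both within the scatter. Among the measured compounds shown here, the only single-point step measured so far is a 1.2-fold lower number from compound 1 to compound 2 (0.09 log units; within the scatter), hydrogen in place of methoxy on an aromatic carbon, and it stays within the scatter. All three numbers therefore sit within the scatter of one another, and no ordering among them can be claimed.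

Compound 4 `C/C(=C\COc1ccccc1)CC/C=C(\C)C1=CC(=O)C(C)(C)O1` differs from compound 2 by a group of 8 heavy atoms (6 carbon, 2 oxygen; one five-membered non-aromatic ring with 1 hetero atom) in place of a group of 8 heavy atoms (6 carbon, 2 oxygen; one five-membered non-aromatic ring with 1 hetero atom), on a double-bonded chain carbon bound to a double-bonded chain carbon and a saturated chain carbon. For the measured compounds named here, none of the measured steps touches this part of the shared core; the one step so far concerns the aromatic ring only, so there is no precedent for the size or direction of this change. Compound 4 is therefore expected near the value of compound 2, at 27 ug/mL with a range of 9 ug/mL to 80 ug/mL. The step of a 1.0-fold lower number from compound 2 to compound 4 (0.01 log units; within the scatter) that this estimate implies is expected to lie within the scatter, but the range is held wide.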

Compound 4, half-maximal inhibitory concentration: 35.2 ug/mL
Compound 4: the middle estimate sits 1.3-fold (0.12 log units) below what was measured; measured number inside the range.
By their numbers in this assay, from the lowest: compounds 3, 2, 1 and 4 (each within the scatter of the next).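

In this assay, the step at this position, on a double-bonded chain carbon bound to a double-bonded chain carbon and a saturated chain carbon, gives a 1.3-fold higher number from compound 2 to compound 4 (0.11 log units; within the scatter) as 5,5-dimethyl-4-oxooxolan-2-yl gives way to a five-membered ring with 2 double bonds outside aromatic rings in place of 1. Among the compounds shown here, this is the first measured change away from the aromatic ring, and compound 2 and compound 4 cannot be told apart on this read-out, so the series tolerates this change in the ring without a measurable shift. No supporting data bear on this result.

Every step measured so far stays within the scatter, so neither the aromatic ring nor this position has yet been shown to affect the read-out. From the compounds shown here alone, whether an amine or a carboxylic acid in place of this ring group, or a longer chain, would give a step beyond the scatter stays open.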